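Chloro in place of hydrogen on compound 2

The source may hold more compounds than are shown below. What is called first, only, known or untested is meant among the compounds shown, and "the series" means these compounds.

Going by the values given here, in a functional assay on K562 cells (Homo sapiens) for inhibition (a lower number here means a stronger inhibitor, a higher number a weaker inhibitor), compound 2 (`CCOc1ccc(Br)cc1-c1cc(Nc2ccccc2)nc(N)n1`) gives 260 nM, the lower of the two numbers so far, and compound 1 (`CCOc1ccc(Br)cc1-c1cc(Nc2ccc(C(=O)NO)cc2)nc(N)n1`) gives 700 nM. Next is compound 3 (`CCOc1ccc(Br)cc1-c1cc(Nc2ccc(Cl)cc2)nc(N)n1`), with chloro in place of hydrogen on an aromatic carbon. Among the compounds with values here, only one measured step bears on this change: a 2.7-fold lower number from compound 1 to compound 2 (0.43 log units; beyond the scatter), modest and beyond the scatter, with hydrogen in place of hydroxycarbamoyl on an aromatic carbon. That step involves a different group, so it offers a rough size but no direction for chloro, and a single step sets no trend. The expected step in this assay is a 1.1-fold lower number from compound 2 to compound 3 (0.03 log units; within the scatter), no larger than the measured one and probably within the scatter. For compound 3 the estimated value is 240 nM, with an expected range of 90 nM to 650 nM.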

Compound 3, half-maximal inhibitory concentration: 50 nM
The estimate for compound 3 lay 4.8-fold (0.68 log units) above the measured number, outside the stated range (below it).
By their numbers in this assay, from the lowest: compound 3; then compound 2; then compound 1.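

In this assay this carbon of the anilino ring proves responsive to a single added atom: chloro in place of hydrogen gives a 5.2-fold lower number from compound 2 to compound 3 (0.72 log units; beyond the scatter) and so reverses the picture left by hydroxycarbamoyl, the only substituent seen there before, which stood above the unsubstituted compound. Set directly against hydroxycarbamoyl at this place, chloro gives a 14-fold lower number from compound 1 to compound 3 (1.15 log units; beyond the scatter) and the three compounds now run chloro, hydrogen, hydroxycarbamoyl from the lowest number, with every step beyond the scatter. Nothing given here bears on the cause of these steps.

From the compounds shown here alone, whether the gain is particular to chloro remains open, since fluoro, methyl, methoxy, an amine or a carboxylic acid at this place could each fall anywhere in that order. Also open, going by these compounds, is whether chloro on another carbon of this ring would give a step of similar size.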